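The compounds below may be only part of what the source reports. "The series", "measured", "known", "first", "only" and "open" are said of these compounds alone.

Measured so far:
Compound 1 `COc1ccc(C)cc1NC(=S)N/N=C/c1ccc2ccccc2n1` reaches only the limit of > 100000 nM in a functional assay on HL-60 cells (Homo sapiens) for antiproliferative activity, read by sulforhodamine B assay, with a stated time of 72 h; a higher number here means a weaker inhibitor, a lower number a stronger inhibitor.
Compound 2 `Fc1cccc(NC(=S)N/N=C/c2ccc3ccccc3n2)c1` gives 43800 nM in this assay.
Compound 3 `NC(=S)N/N=C/c1cc2ccccc2s1` also reaches only the limit of > 100000 nM in this assay.

Among the compounds with values here, compound 2 thus stands as the one compound with a real number, while the other two sit at the limit of > 100000 nM in this assay, at which 2 of the 3 values shown sit. Compound 4 `N#Cc1ccc(NC(=S)N/N=C/c2ccc3ccccc3n2)cc1` has not yet been measured in this assay. It differs from compound 2 in one place: 4-cyanophenyl in place of 3-fluorophenyl on an amide-type nitrogen. Within the data shown here, no measured pair shows the effect of such a change, so the expectation rests on compound 2 alone. The step from compound 2 to compound 4 is expected to be small, a 1.1-fold lower number from compound 2 to compound 4 (0.04 log units; within the scatter), within the usual scatter in either direction. Compound 4 is therefore estimated at 40000 nM, with a range from 12000 nM to 100000 nM.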

Compound 4, half-maximal inhibitory concentration: 4660 nM
For compound 4 the middle estimate is 8.6-fold (0.93 log units) above the measured one; the measured number lies below the stated range.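

The aryl group on the amide-type nitrogen clearly matters in this assay: 4-cyanophenyl in place of 3-fluorophenyl gives a 9.4-fold lower number from compound 2 to compound 4 (0.97 log units; beyond the scatter). Within the data shown here, this is the first measured step at this position, and it lies beyond the scatter. It remains a single step on a narrow base, since few values here are real numbers: the limit of > 100000 nM in this assay, at which 2 of the 4 values shown sit.

On these data alone, whether the lower number belongs to the nitrile itself, or to the whole change of aryl group, stays open. Also unknown is how an amine or a carboxylic acid would fare in place of the nitrile.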